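The compounds below may be only part of what the source reports. "The series", "measured", "known", "first", "only" and "open" are said of these compounds alone.

The series shares one core, seen in compound 1 `O=C(Nc1cccc(-c2oc3cc(-c4ccc(F)cc4)ccc3c(=O)c2O)c1)c1ccc(F)cc1`, compound 2 `O=C(Nc1cccc(-c2oc3cc(-c4ccc(F)cc4)ccc3c(=O)c2O)c1)c1ccc(Br)cc1` and compound 3 `Cc1cc(C(=O)Nc2cccc(-c3oc4cc(-c5ccc(F)cc5)ccc4c(=O)c3O)c2)ccc1F`. In a functional assay on MDA-MB-231 cells (Homo sapiens) for antiproliferative activity, read by CCK-8 assay, with a stated time of 72 h (on this read-out lower numbers stand for stronger inhibition and higher numbers for weaker inhibition), compound 1 gives 16000 nM, compound 2 gives 24900 nM and compound 3 gives 7440 nM, the lowest of the three numbers. Compound 4 `O=C(Nc1cccc(-c2oc3cc(-c4ccc(F)cc4)ccc3c(=O)c2O)c1)c1ccc(-c2ccccc2)cc1` is not yet measured; it differs from compound 3 in that (4-phenylphenyl in place of 4-fluoro-3-methylphenyl on a carbonyl carbon). Among the compounds with values here, no measured step is a direct analogue: a 1.6-fold higher number from compound 1 to compound 2 (0.19 log units; within the scatter) and a 2.2-fold lower number from compound 1 to compound 3 (0.33 log units; beyond the scatter) concern single substituent changes on the ring at the carbonyl carbon, and a 3.3-fold lower number from compound 2 to compound 3 (0.52 log units; beyond the scatter) is the only exchange of that whole ring. For compound 4 a step of comparable size, in uncertain direction, is expected, a 1.2-fold higher number from compound 3 to compound 4 (0.08 log units; within the scatter). Compound 4 is therefore estimated at 9000 nM, with a likely range from 3000 nM to 30000 nM.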

Compound 4, half-maximal inhibitory concentration: 63200 nM
Beside the measured number, compound 4's estimate is 7.0-fold (0.85 log units) below it; the whole stated range lies below it.
By their numbers in this assay, from the lowest: compound 3; then compounds 1 and 2 (each within the scatter of the next); then compound 4.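

In this assay, 4-phenylphenyl on the carbonyl carbon gives higher numbers than each earlier ring: an 8.5-fold higher number from compound 3 to compound 4 (0.93 log units; beyond the scatter), a 2.5-fold higher number from compound 2 to compound 4 (0.40 log units; beyond the scatter) and a 4.0-fold higher number from compound 1 to compound 4 (0.60 log units; beyond the scatter). The step from compound 3 is the largest seen so far at this position, and replacing bromo or fluoro with phenyl is beyond the scatter in both cases. No available evidence explains this loss.

On these data alone, it remains open whether methoxy or morpholine in place of the added phenyl would restore lower numbers. As far as these compounds go, it is also open whether an amine or a carboxylic acid on the 4-phenylphenyl group would change the step.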